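The compounds below may be only part of what the source reports. "The series", "measured", "known", "first", "only" and "open" are said of these compounds alone.

In a functional assay on BXPC-3 cells (Homo sapiens) for antiproliferative activity, read by MTT assay, with a stated time of 24 h (on this read-out higher numbers stand for weaker inhibition and lower numbers for stronger inhibition), compound 1 `CCn1c(C(=O)N[C@@H](CC(=O)OC)C(=O)OC)ccc1C(CC)(CC)c1ccc(OCS(=O)(=O)c2ccccc2)c(C)c1` gives only a limit, > 50000 nM. Compound 2 `CCn1c(C(=O)N[C@H](CO)C(C)C)ccc1C(CC)(CC)c1ccc(OCS(=O)(=O)c2ccccc2)c(C)c1` gives 7720 nM and compound 3 `CCn1c(C(=O)N[C@@H](CO)C(C)C)ccc1C(CC)(CC)c1ccc(OCS(=O)(=O)c2ccccc2)c(C)c1` gives 13200 nM, two numbers that lie within the scatter of each other. Given (the fact that compounds 2 and 3 differ only in the configuration as drawn), their step is a 1.7-fold higher number from compound 2 to compound 3 (0.23 log units; within the scatter). Compound 4 `CCn1c(C(=O)N[C@@H](CO)CCCO)ccc1C(CC)(CC)c1ccc(OCS(=O)(=O)c2ccccc2)c(C)c1` departs from compound 3 in the side chain: 3-hydroxypropyl in place of isopropyl on a saturated chain carbon bound to an amide-type nitrogen and a saturated chain carbon. Within the data shown here, no measured step makes this change alone. The nearest evidence is the replacement of the whole amide substituent, which gave an at least 6.4-fold lower number from compound 1 to compound 2 (0.81 log units; beyond the scatter) and an at least 3.7-fold lower number from compound 1 to compound 3 (0.57 log units; beyond the scatter). Both of those steps rest on (the limit of > 50000 nM in this assay, at which 1 of the 3 values shown sits), so they fix only a minimum size and replace far more of the substituent than compound 4 does. Compound 4 also keeps the hydroxymethyl group shared by compound 2 and compound 3. On these data alone, a large shift is therefore not expected in this assay, and the direction remains open. The expected change is a 1.2-fold higher number from compound 3 to compound 4 (0.08 log units; within the scatter), which is no step beyond the scatter. For compound 4 the estimated value is 16000 nM, with an expected range of 5500 nM to 45000 nM.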

Compound 4, half-maximal inhibitory concentration: 16400 nM
Compound 4: middle estimate off by 1.0-fold (0.01 log units), on the low side, and the stated range covers the measured number.
By their numbers in this assay, from the lowest: compounds 2, 3 and 4 (each within the scatter of the next, the first and the last beyond it). At a limit, above all of these: compound 1.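

At this saturated chain carbon bound to an amide-type nitrogen and a saturated chain carbon, 3-hydroxypropyl in place of isopropyl gives, in this assay, a 1.2-fold higher number from compound 3 to compound 4 (0.09 log units; within the scatter), so this swap alone leaves the read-out inside the scatter. Against compound 2, the result is a 2.1-fold higher number from compound 2 to compound 4 (0.33 log units; beyond the scatter), but that step replaces the whole group on the amide-type nitrogen, so it cannot be credited to the side chain alone. The step of an at least 3.0-fold lower number from compound 1 to compound 4 (0.48 log units; beyond the scatter) fixes only a minimum size, since the value of compound 1 is a limit: the limit of > 50000 nM in this assay, at which 1 of the 4 values shown sits.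

The compounds shown leave open whether an amine, a carboxylic acid or a longer chain at this place would also stay within the scatter of compound 3. A plain propyl group would be needed to separate the hydroxyl of 3-hydroxypropyl from the chain that carries it.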